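The compounds below may be only part of what the source reports. "The series", "measured", "known", "first", "only" and "open" are said of these compounds alone.

Compound 1 `COc1cc(-c2cc(/C=C/C(=O)c3ccc(N)cc3)[nH]n2)cc(OC)c1OC` and compound 2 `COc1ccc(-c2cc(/C=C/C(=O)c3ccc(OC)c(OC)c3)[nH]n2)cc1` have both been tested in a functional assay on MDA-MB-231 cells (Homo sapiens) for cytotoxicity, read by sulforhodamine B assay, with a stated time of 48 h, tested at 1 uM; a lower number here means a stronger effect, a higher number a weaker effect of the compound at the concentration tested. In this assay compound 1 gives 70%, and compound 2 gives 79%. Compound 1 holds the lowest of these two numbers, but the nearest number, that of compound 2, sits only slightly higher and within the scatter of this kind of measurement, so the two compounds cannot be told apart on this evidence. Among the compounds with values here, no pair of measured compounds differs in only one place, so no single step between measured compounds is available to guide a prediction.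

Compound 3 `COc1cc(-c2cc(/C=C/C(=O)c3ccc(Cl)c(Cl)c3)[nH]n2)cc(OC)c1OC` is the next compound to be measured in this assay. It differs from compound 1 by 3,4-dichlorophenyl in place of 4-aminophenyl on a carbonyl carbon. Within the data shown here, with no measured step to rest on, no direction can be read from the data, and the step of a number 2 percentage points lower from compound 1 to compound 3 (within the scatter) is expected to stay small, not beyond the scatter in either direction. Compound 3 is therefore estimated to give 68% in this assay, with a range from 45% to 92%.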

Compound 3, a percentage reported as activity, at one concentration (the size of the read-out at that concentration, not a potency): 89%
Beside the measured number, compound 3's estimate is 21 percentage points below it; the measured number falls inside the stated range.
By their numbers in this assay, from the lowest: compounds 1, 2 and 3 (each within the scatter of the next, the first and the last beyond it).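

In this assay, within the data shown here, the change from 4-aminophenyl to 3,4-dichlorophenyl on a carbonyl carbon gives the first step that can be read at this position, a number 19 percentage points higher from compound 1 to compound 3 (beyond the scatter), a modest step toward a weaker effect at the concentration tested. Among these compounds, it shows that, on the core of compound 1, the group at this position is not indifferent, which the earlier compounds, differing in more than one place, could not show. No measurement shown here bears on why the number moves, and the step replaces the whole ring substitution at once, changing the nitrogen, the two chlorines and the counts of hydrogen-bond donors and acceptors together.

The compounds shown leave open whether the step follows the loss of the amine or the arrival of the chlorines, a question that a plain phenyl or a 4-chlorophenyl on the same carbonyl carbon would begin to separate. They also leave open whether a group such as 4-hydroxyphenyl would stay close to compound 1 or move toward compound 3.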